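This account rests on a few compounds, and the source may have more. Where it says the series, first, only, none or still open, it means among the compounds named here.

Measured compounds:
Compound 1, `O=c1[nH]cnc2c1c(-c1ccoc1)cn2[C@@H]1O[C@H](CO)[C@@H](O)[C@H]1O`, reached only a limit in a functional assay on HeLa S3 cells (Homo sapiens) for antiproliferative activity, read by XTT assay, with a stated time of 72 h (a lower number here means a stronger inhibitor, a higher number a weaker inhibitor), recorded as > 20000 nM.
Compound 2, `Cc1nc(N)c2c(-c3cccs3)cn([C@@H]3O[C@H](CO)[C@@H](O)[C@H]3O)c2n1`, also reached only a limit in this assay, recorded as > 20000 nM.
Compound 3, `CSc1ncnc2c1c(-c1ccsc1)cn2[C@@H]1O[C@H](CO)[C@@H](O)[C@H]1O`, likewise reached only a limit in this assay, recorded as > 20000 nM.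

Compound 2 therefore has no number of its own to stand on in this assay: its result is a limit, and the same holds for every measured compound, as the limit of > 20000 nM in this assay, at which 3 of the 3 values shown sit, shows. For the measured compounds named here, no step between two measured compounds can be computed, as none of the three pairs has a number on both sides. Compound 4, `Cc1nc(N)c2c(-c3ccoc3)cn([C@@H]3O[C@H](CO)[C@@H](O)[C@H]3O)c2n1`, differs from compound 2 by furan-3-yl in place of thiophen-2-yl on an aromatic carbon. The expected step in this assay is none beyond the scatter, because the limit of > 20000 nM in this assay, at which 3 of the 3 values shown sit, leaves no number for the change to move away from. Compound 1 already carries furan-3-yl on a different core and stops at > 20000 nM. Compound 4 is expected to give 30000 nM, between 10000 nM and 100000 nM, most likely once more as a limit. The expected step is a step that the limit leaves unreadable from compound 2 to compound 4.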

Compound 4, half-maximal inhibitory concentration: > 20000 nM
Compound 4: only a limit was reported (the forecaster's own chance of this, stated with the estimate: 85%); the middle value lies beyond the limit too.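

Compound 2 and compound 4 each ended in a limit rather than a number, so no step can be read for furan-3-yl in place of thiophen-2-yl: the limit of > 20000 nM in this assay, at which 4 of the 4 values shown sit.

The compounds shown leave open whether either group affects activity in this assay, since none gives a measured number there.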